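Methyl for nitro on the aryloxy group: compound 3

The source may report more compounds than this note shows. Statements on the series, on what has been measured and on what is new or still open speak of the compounds shown alone.

Compound 1 `COc1cc2c(cc1OC)CN(S(=O)(=O)c1ccc(-n3cc(COc4ccccc4C(C)=O)nn3)cc1)CC2` gives in a functional assay on MOLT-3 cells (Homo sapiens) for cytotoxicity, read by MTT assay, with a stated time of 48 h (a higher number here means a weaker inhibitor, a lower number a stronger inhibitor), only the limit > 50 ug/mL.
Compound 2 `COc1cc2c(cc1OC)CN(S(=O)(=O)c1ccc(-n3cc(COc4ccc([N+](=O)[O-])cc4)nn3)cc1)CC2` gives in this assay only the limit > 50 ug/mL.

Among the measured compounds shown here, compound 2 stands at the limit, not at a number, and so does the one other value shown, as the limit of > 50 ug/mL in this assay, at which 2 of the 2 values shown sit, records. The step that the two limits leave unreadable from compound 1 to compound 2 therefore carries no readable size. Compound 3 `COc1cc2c(cc1OC)CN(S(=O)(=O)c1ccc(-n3cc(COc4ccc(C)cc4)nn3)cc1)CC2` differs from compound 2 by methyl in place of nitro on an aromatic carbon. For the measured compounds named here, no measured step bears on this change, so no direction can be read from the data for this assay. Compound 3 is expected at 60 ug/mL, within 20 ug/mL to 200 ug/mL, most likely again reported as a limit. The expected step is a step that the limit leaves unreadable from compound 2 to compound 3.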

Compound 3, half-maximal inhibitory concentration: > 50 ug/mL
Compound 3: a limit, no number; the forecaster's own chance of this, stated with the estimate: 75%; the middle value is on the limit's open side.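

No new step can be read between compound 3 and either compound 1 or compound 2, since all three stand at a limit, not a number: the limit of > 50 ug/mL in this assay, at which 3 of the 3 values shown sit.

The compounds shown leave open how the three aryloxy groups rank and whether any compound on the shared core gives a measurable value.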